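Exchanging the Piperidine for an Oxopiperazine on Compound 2

The source may hold more compounds than are shown below. What is called first, only, known or untested is meant among the compounds shown, and "the series" means these compounds.

Compound 2 `CC(C)N1CCC(c2ccc3c(c2)oc(=O)n3C(=O)NCCCCc2ccccc2)CC1` shows the lowest number of the three measured compounds in an assay on HEK293 cells for inhibition of acid ceramidase (Homo sapiens), read by fluorescence, with stated times of 10 min and 3 h (a lower number here means a stronger inhibitor, a higher number a weaker inhibitor), giving 94 nM. Compound 1 `CC(=O)N1CCc2oc(=O)n(C(=O)NCCCCc3ccccc3)c2C1` gives 293 nM in this assay, a gap beyond the scatter, and compound 3 `O=C(NCCCCc1ccccc1)n1c2c(oc1=O)CCN(Cc1ccccc1)C2` gives 436 nM, the furthest of the three from compound 2. Among the compounds with values here, the only step between measured compounds that differ in one place, a 1.5-fold higher number from compound 1 to compound 3 (0.17 log units; within the scatter), concerns a benzyl in place of an acetyl on an amine nitrogen in a ring, a change with no counterpart in the step now considered.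

Compound 4 `CN1CCN(c2ccc3c(c2)oc(=O)n3C(=O)NCCCCc2ccccc2)CC1=O` differs from compound 2 in one place: 4-methyl-3-oxopiperazin-1-yl in place of 1-isopropylpiperidin-4-yl on an aromatic carbon. Within the data shown here, no measured step bears directly on this exchange; compound 1 and compound 3 share neither the core of compound 2 nor a group of this kind on an aromatic carbon. Among the measured compounds shown here, the expectation therefore rests on compound 2 alone, with a modest weakening allowed for because the entering group is not the one that gave compound 2 its 94 nM. The step of a 2.1-fold higher number from compound 2 to compound 4 (0.33 log units; beyond the scatter) is expected to be small, near the edge of the scatter, toward a higher number. Compound 4 is estimated at 200 nM, with a range from 60 nM to 700 nM.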

Compound 4, half-maximal inhibitory concentration: 92 nM
Compound 4: middle estimate off by 2.2-fold (0.34 log units), on the high side; low and high end bracket the measured number.
By their numbers in this assay, from the lowest: compounds 4 and 2 (each within the scatter of the next); then compounds 1 and 3 (each within the scatter of the next).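

The step of a 1.0-fold lower number from compound 2 to compound 4 (0.01 log units; within the scatter) shows that, in this assay, this aromatic carbon accepts either group with the two compounds standing within the scatter of each other. The groups are not alike in what can be counted: 4-methyl-3-oxopiperazin-1-yl brings a ring with 2 hetero atoms in place of 1, a double bond outside aromatic rings and 2 hydrogen-bond acceptors in place of 1, yet for this one pair the number does not move beyond the scatter. Nothing available here accounts for the two groups reading alike.

The compounds shown place only these two six-membered non-aromatic rings on this carbon, so they leave open how this assay would read a group of another kind there, such as a carboxylic acid or an open-chain amine. Also open, going by these compounds, is whether a longer chain could take the place of the methyl on 4-methyl-3-oxopiperazin-1-yl, and whether the same exchange would read alike on another core.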